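Benzoxaborole amides: methoxy addition on the aryl amide

This account rests on a few compounds, and the source may have more. Where it says the series, first, only, none or still open, it means among the compounds named here.

Measured so far:
compound 1 `O=C(CCc1cccc2c1B(O)OC2)Nc1ccccc1` 200 nM
compound 2 `COc1ccccc1NC(=O)CCc1cccc2c1B(O)OC2` 200 nM
compound 3 `COc1cccc(-c2cccc(NC(=O)CCc3ccc4c(c3)B(O)OC4)c2)c1` 62000 nM

In a functional assay on SK-OV-3 cells (Homo sapiens) for antiproliferative activity, read by MTT assay, with a stated time of 72 h (on this read-out lower numbers stand for stronger inhibition and higher numbers for weaker inhibition), compound 1 gives 200 nM and compound 2 gives 200 nM. The change between them is methoxy in place of hydrogen on an aromatic carbon and the step is no change at the digits printed from compound 1 to compound 2 (within the scatter). Compound 3 carries a different core; the difference between the two cores is not broken down here. In this assay compound 3 gives 62000 nM, the highest number of the three.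

Compound 4 `COc1cc(OC)cc(-c2cccc(NC(=O)CCc3ccc4c(c3)B(O)OC4)c2)c1` is not yet measured. It differs from compound 3 by methoxy in place of hydrogen on an aromatic carbon. This is the same kind of change as that from compound 1 to compound 2, but the place differs: there the entering group sat ortho to a large group, here it sits meta to a large group and meta to a methoxy group. Among the compounds with values here, the only precedent is no change at the digits printed from compound 1 to compound 2 (within the scatter), which rests on one pair on a different core. On that basis the expected step is no change at the digits printed from compound 3 to compound 4 (within the scatter). For compound 4 in this assay the estimate is 62000 nM, with a range from 20000 nM to 200000 nM.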

Compound 4, half-maximal inhibitory concentration: 29000 nM
Compound 4: middle estimate off by 2.1-fold (0.33 log units), on the high side; low and high end bracket the measured number.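

In this assay, the added methoxy gives a 2.1-fold lower number from compound 3 to compound 4 (0.33 log units; beyond the scatter), a modest step on the core of compound 3. Set beside the earlier pair, the step does not separate from it, so the two cores give no sign of a different response to this change: the same change on two cores in this assay, no change at the digits printed (within the scatter) from compound 1 to compound 2 and a 2.1-fold lower number (0.33 log units; beyond the scatter) from compound 3 to compound 4, 2.1-fold (0.33 log units) apart, within the scatter of two such steps. Within the data shown here, this supports carrying the change from one core to the other without expecting a large shift, but it rests on only two pairs with the entering group in a different place on each, so it does not show that the step is independent of core or place.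

The compounds shown leave open how an amine or a carboxylic acid in place of the methoxy would read on either core, and whether a longer chain between the amide and the core would shift the numbers. They also leave open which structural feature accounts for the difference in numbers between the two cores.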